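The source may report more compounds than this note shows. Statements on the series, on what has been measured and on what is new or still open speak of the compounds shown alone.

Measured compounds:
Compound 1 `Cc1ccccc1-n1nncc1CN1C(=O)C2(C(C#N)=C(N)Oc3c2c2nc4ccccc4nc2c2ccccc32)c2ccccc21` — in a functional assay on HCT-116 cells (Homo sapiens) for antiproliferative activity, read by MTT assay, with a stated time of 48 h (on this read-out lower numbers stand for stronger inhibition and higher numbers for weaker inhibition), compound 1 gives > 50000 nM, a limit of the assay and not a number.
Compound 2 `N#CC1=C(N)Oc2c(c3nc4ccccc4nc3c3ccccc23)C12C(=O)N(Cc1cnnn1-c1ccc(Cl)cc1)c1ccccc12` — in this assay compound 2 gives > 50000 nM, likewise only a limit.

On the numbers shown, compound 1 therefore stands only at a limit, and nothing finer is known about it. Within the data shown here, the one measured step, a step that the two limits leave unreadable from compound 1 to compound 2, cannot be sized: the limit of > 50000 nM in this assay, at which 2 of the 2 values shown sit, shows both of its ends sitting at the same limit. Compound 3 `N#CC1=C(N)Oc2c(c3nc4ccccc4nc3c3ccccc23)C12C(=O)N(Cc1cnnn1-c1ccccc1Cl)c1ccccc12` differs from compound 1 by chloro in place of methyl on an aromatic carbon — chloro in place of methyl on an aromatic carbon of a six-membered aromatic ring of carbon only, read one bond further out as 2-methylphenyl to 2-chlorophenyl. The measured step also exchanges a methylphenyl for a chlorophenyl, so it is the only one that bears here, and it gives no readable size or direction. No step beyond the scatter is expected, so a number no higher from compound 1 to compound 3 (the limit leaves the size open) is estimated to be essentially none. Compound 3 is estimated at 50000 nM, between 20000 nM and 100000 nM, most probably again reported only as a limit.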

Compound 3, half-maximal inhibitory concentration: > 50000 nM
Compound 3 gave a limit, no number (the forecaster's own chance of this, stated with the estimate: 85%); the middle value sits exactly at the limit.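

Compound 3 adds no readable step: its comparisons with compound 1 and compound 2 cannot be sized, as all three compounds rest on one limit of the assay: the limit of > 50000 nM in this assay, at which 3 of the 3 values shown sit.

The compounds shown leave open whether any change to the shared core would give a measurable number in this assay.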